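This account rests on a few compounds, and the source may have more. Where it says the series, first, only, none or still open, it means among the compounds named here.

Compounds measured in a functional assay on PC-3 cells (Homo sapiens) for inhibition, read by MTT assay, with a stated time of 72 h; a higher number here means a weaker inhibitor, a lower number a stronger inhibitor:

Compound 1 `O=C(CSc1nc(Nc2ccccc2)c2ccccc2n1)Nc1ccccc1Cl` gives 14600 nM.
Compound 2 `O=C(CSc1nc(Nc2ccccc2)c2ccccc2n1)Nc1cccc(F)c1` gives 15600 nM.
Compound 3 `O=C(CSc1nc(Nc2ccccc2)c2ccccc2n1)Nc1cccc(Cl)c1` gives 12600 nM.

The three numbers lie close together. The steps of a 1.2-fold lower number from compound 1 to compound 3 (0.06 log units; within the scatter) and a 1.2-fold lower number from compound 2 to compound 3 (0.09 log units; within the scatter) both stay within the scatter, so compound 3 cannot be set apart from the other two on these numbers; it merely carries the smallest of three values that are, for practical purposes, the same.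

Compound 4 `O=C(CSc1nc(Nc2ccccc2)c2ccccc2n1)Nc1cccc(Br)c1` is the next member of the series. It differs from compound 3 by bromo in place of chloro on an aromatic carbon. Among the compounds with values here, the one measured step that bears directly on a halogen exchange at this position is a 1.2-fold lower number from compound 2 to compound 3 (0.09 log units; within the scatter), which was within the scatter. The step of a 1.2-fold lower number from compound 1 to compound 3 (0.06 log units; within the scatter), which moved the chloro group from one position of the ring to another, was also within the scatter. Nothing among these compounds suggests that a change of halogen at this ring carbon moves the number in this assay beyond the usual scatter, and the expected step of a 1.1-fold lower number from compound 3 to compound 4 (0.04 log units; within the scatter) is therefore one of no clear direction. Compound 4 is accordingly estimated at 11500 nM in this assay, with a range from 6000 nM to 22000 nM.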

Compound 4, half-maximal inhibitory concentration: 11400 nM
Beside the measured number, compound 4's estimate is 1.0-fold (0.00 log units) above it; low and high end bracket the measured number.
By their numbers in this assay, from the lowest: compounds 4, 3, 1 and 2 (each within the scatter of the next).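

With 3-bromophenyl added, three halogens can now be compared at this ring carbon in this assay: the exchange of chloro for bromo gives a 1.1-fold lower number from compound 3 to compound 4 (0.04 log units; within the scatter) and the wider exchange of fluoro for bromo gives a 1.4-fold lower number from compound 2 to compound 4 (0.14 log units; within the scatter) and so even the two halogens furthest apart in size among these compounds cannot be told apart on these numbers. The step that changes both the halogen and its place on the ring, from 2-chlorophenyl to 3-bromophenyl, gives a 1.3-fold lower number from compound 1 to compound 4 (0.11 log units; within the scatter) and also stays within the scatter, so among these four compounds neither the identity of the halogen nor the two placements shown separates one compound from another. Nothing measured here offers an explanation for this flat result.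

The compounds shown leave open whether a group other than a halogen at this ring carbon, such as an amine, a methoxy group or a carboxylic acid, would move the number beyond the scatter. They also leave open whether the same holds for a bromo group in the position of the chloro group of compound 1, or for changes made elsewhere on the shared core, such as a longer chain in place of the link to the amide.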